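Trading 3,4-Dimethoxyphenyl for Ethylcarbamoyl on compound 3

A few compounds are considered here, and "the series" means these few. Any claim that something is new, unique, unknown or untested is made for them only; others in the source may bear on it.

So far, three related compounds have numbers in an ADME assay on HeLa cells (Homo sapiens) for cytotoxicity, read by crystal violet staining, with a stated time of 72 h; on this read-out higher numbers stand for lower toxicity in this test and lower numbers for higher toxicity in this test. Compound 3 `COc1ccc(-c2cc(CCCOc3c(C)cc(-c4noc(C(F)(F)F)n4)cc3C)on2)cc1OC` gives 41900 nM. Compound 1 `CCOC(=O)c1cc(CCCOc2ccc(-c3noc(C(F)(F)F)n3)cc2C(F)(F)F)on1` gives 28400 nM, which lies within the usual scatter of the number for compound 3. Compound 2 `Cc1cc(-c2noc(C(F)(F)F)n2)cc(C)c1OCCCc1cc(C(=O)OC(C)C)no1` gives 17900 nM. For the measured compounds named here, the only measured change in a single place is a 2.3-fold higher number from compound 2 to compound 3 (0.37 log units; beyond the scatter). It is modest but beyond the scatter, so compound 3 stands with compound 1 and apart from compound 2.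

Compound 4 `CCNC(=O)c1cc(CCCOc2c(C)cc(-c3noc(C(F)(F)F)n3)cc2C)on1` has not been measured yet. It carries ethylcarbamoyl in place of 3,4-dimethoxyphenyl on an aromatic carbon. This swap removes the group that the measured step introduced, from the same aromatic carbon. Losing that group should therefore move the number back toward compound 2 at 17900 nM. Going by the values given here, no compound with ethylcarbamoyl has been tested in this assay, so this guide is imperfect and the range must stay wide. A small step down is expected, a 1.9-fold lower number from compound 3 to compound 4 (0.28 log units; within the scatter). For compound 4 the estimated value is 22000 nM, with an expected range from 10000 nM to 45000 nM.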

Compound 4, half-maximal cytotoxic concentration: > 100000 nM
Compound 4 gave a limit, no number; the forecaster's own chance of this, stated with the estimate: 10%; middle value at least 4.5-fold (0.65 log units) from the limit.
By their numbers in this assay, from the lowest: compounds 2, 1 and 3 (each within the scatter of the next, the first and the last beyond it). At a limit, above all of these: compound 4.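

In this assay compound 4 gives a limit of the assay and not a number: the limit of > 100000 nM in this assay, at which 1 of the 4 values shown sits. For the compounds shown here, on this aromatic carbon, next to the ring nitrogen, ethylcarbamoyl in place of 3,4-dimethoxyphenyl gives an at least 2.3-fold higher number from compound 3 to compound 4 (0.37 log units; beyond the scatter), so this position can carry a larger change in the read-out than the one earlier step suggested, even with a group of fewer heavy atoms and no ring. The comparison with the ester is more exact, since only the atoms on the carbonyl carbon differ: ethylamino in place of isopropoxy gives an at least 5.5-fold higher number from compound 2 to compound 4 (0.74 log units; beyond the scatter), which shows that the group attached to this carbonyl carbon matters in this test, and that a carbonyl at this position does not by itself set the result.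

The compounds shown leave open whether the amide hydrogen is needed, which a dimethylamino group on the same carbonyl carbon would address. They also leave open how a carboxylic acid or a longer chain on the amide nitrogen would read in this assay.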